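Swapping the Aryl Group on the Ring Nitrogen

The compounds below may be only part of what the source reports. "The series", "measured", "known", "first", "only" and "open" are said of these compounds alone.

Three compounds share one core and differ only in the aryl group on an amide-type nitrogen in a ring. Compound 1 `COc1ccc(C)cc1N1C(=O)CSC1c1cccc(C(=O)NCCCCc2ccccc2)c1` gives 30% in a functional assay on U2OS cells (Homo sapiens) for inhibition, read by CCK-8 assay, with a stated time of 72 h, tested at 1 uM; a lower number here means less inhibition, a higher number more inhibition at the concentration tested (going by the name of the read-out). Compound 2 `COc1cccc(OC)c1N1C(=O)CSC1c1cccc(C(=O)NCCCCc2ccccc2)c1` gives 41% in this assay, and compound 3 `O=C(NCCCCc1ccccc1)c1cccc(C2SCC(=O)N2c2ccccc2F)c1` gives 38% in this assay, standing second highest of the three but within the scatter of both others. The step of a number 11 percentage points higher from compound 1 to compound 2 (beyond the scatter) is modest, while a number 8 percentage points higher from compound 1 to compound 3 (within the scatter) and a number 3 percentage points lower from compound 2 to compound 3 (within the scatter) stay within the scatter. Compound 4 `COc1ccc(N2C(=O)CSC2c2cccc(C(=O)NCCCCc3ccccc3)c2)c(OC)c1` carries 2,4-dimethoxyphenyl in place of 2-fluorophenyl on an amide-type nitrogen in a ring. Because a number 3 percentage points lower from compound 2 to compound 3 (within the scatter) stayed within the scatter, the expected step is a number 2 percentage points higher from compound 3 to compound 4 (within the scatter), none beyond the scatter. Compound 4 is therefore expected to give 40%, between 25% and 55%.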

Compound 4, a percentage reported as inhibition, at one concentration (the size of the read-out at that concentration, not a potency): 37%
Beside the measured number, compound 4's estimate is 3 percentage points above it; low and high end bracket the measured number.
By their numbers in this assay, from the lowest: compounds 1, 4, 3 and 2 (each within the scatter of the next, the first and the last beyond it).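

With 2,4-dimethoxyphenyl at this position, this assay gives a number 1 percentage points lower from compound 3 to compound 4 (within the scatter), a number 4 percentage points lower from compound 2 to compound 4 (within the scatter) and a number 7 percentage points higher from compound 1 to compound 4 (within the scatter). On the ring nitrogen, then, exchanging 2-fluorophenyl for a larger group carrying hydrogen-bond acceptors produces no step beyond the scatter, and neither does exchanging 2,6-dimethoxyphenyl for this isomer. No evidence is available to explain these readings. The compounds shown leave open what a carboxylic acid or an amine on this phenyl ring would give, and whether a pyridine ring or a plain alkyl chain could replace the phenyl ring.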